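From Fluoro to Bromo on an Aromatic Ring

The source may report more compounds than this note shows. Statements on the series, on what has been measured and on what is new or still open speak of the compounds shown alone.

In a functional assay on CCRF-CEM cells (Homo sapiens) (on this read-out lower numbers stand for stronger inhibition and higher numbers for weaker inhibition), compound 3 `CN(C)CC1CCC/C(=C\c2ccc(OC(=O)/C=C/c3ccc(F)cc3)cc2)C1=O` gives 6000 nM. That value lies within the scatter of compound 2 `Cc1ccc(/C=C/C(=O)Oc2ccc(/C=C3\CCCC(CN(C)C)C3=O)cc2)cc1` at 7020 nM, whereas compound 1 `O=C(/C=C/c1ccc(Br)cc1)Oc1ccc(/C=C2\CCCCC2=O)cc1` reads far higher at 131000 nM.

The unmeasured compound 4 `CN(C)CC1CCC/C(=C\c2ccc(OC(=O)/C=C/c3ccc(Br)cc3)cc2)C1=O` differs from compound 3 by one substituent: bromo in place of fluoro on an aromatic carbon of a six-membered aromatic ring of carbon only, para to a large group (bromo in place of fluoro on an aromatic carbon). For the measured compounds named here, only one measured step bears directly on this swap: a 1.2-fold lower number from compound 2 to compound 3 (0.07 log units; within the scatter), with fluoro in place of methyl on an aromatic carbon, and it stays within the scatter. Compound 1 also carries a bromo but differs from compound 4 elsewhere in the structure, so the two do not form a clean comparison.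

With a single step as a guide, no change beyond the scatter is expected in this assay. The estimated change is a 1.1-fold lower number from compound 3 to compound 4 (0.04 log units; within the scatter). The expected value for compound 4 is 5500 nM, within an estimated range of 2500 nM to 12000 nM.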

Compound 4, half-maximal inhibitory concentration: 4440 nM
Compound 4: middle estimate off by 1.2-fold (0.09 log units), on the high side; the range from low to high includes it.
By their numbers in this assay, from the lowest: compounds 4, 3 and 2 (each within the scatter of the next); then compound 1.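

At this place on the aromatic ring, para to a large group, the compounds now show methyl, fluoro and bromo on the same frame, and both a 1.4-fold lower number from compound 3 to compound 4 (0.13 log units; within the scatter) and a 1.6-fold lower number from compound 2 to compound 4 (0.20 log units; within the scatter) stay within the scatter in this assay. Across these three substituents, the read-out therefore shows no clear response to the swap. The (dimethylamino)methyl group gives the first clean view of the saturated ring carbon: with bromo held fixed, there is a 30-fold lower number from compound 1 to compound 4 (1.47 log units; beyond the scatter) for adding that group in place of hydrogen.

No measurement here explains either result. Going by these compounds, it remains open whether a carboxylic acid or an amine at the aromatic position would also stay within the scatter, and whether a longer chain on the saturated ring carbon would keep the large step.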